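Two Chlorines Enter the Outer Ring: An Estimate

This account rests on a few compounds, and the source may have more. Where it says the series, first, only, none or still open, it means among the compounds named here.

The measured compounds and their numbers:
compound 1, `COc1cc(-n2cnc3ccc(-c4ccccc4)cc32)cc(OC)c1OC`: 2290 nM
compound 2, `COc1cc(-n2cnc3ccc(-c4cccc(C)c4)cc32)cc(OC)c1OC`: 360 nM
compound 3, `COc1cc(-n2cnc3ccc(-c4cccc([N+](=O)[O-])c4)cc32)cc(OC)c1OC`: 4560 nM

All three were tested in a functional assay on MCF7 cells (Homo sapiens) for antiproliferative activity, read by MTT assay, with a stated time of 72 h; a lower number here means a stronger inhibitor, a higher number a weaker inhibitor. Compound 1 stands second highest of the three numbers; compound 3 is nearest to it, and compound 2 is furthest. The step of a 2.0-fold higher number from compound 1 to compound 3 (0.30 log units; within the scatter) lies within the scatter, so compound 1 and compound 3 cannot be ordered. The step of a 6.4-fold lower number from compound 1 to compound 2 (0.80 log units; beyond the scatter) is beyond the scatter, and the step of a 13-fold higher number from compound 2 to compound 3 (1.10 log units; beyond the scatter) is larger still.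

Compound 4, `COc1cc(-n2cnc3ccc(-c4ccc(Cl)cc4Cl)cc32)cc(OC)c1OC`, differs from compound 1 in one place: 2,4-dichlorophenyl in place of phenyl on an aromatic carbon. The outer ring now carries two chlorines.

Within the data shown here, no measured step involves chlorine, and no measured step adds two groups at once, so the only guidance is that small changes on this ring have moved the number in both directions. The methyl step from compound 1 to compound 2 lowered the number modestly; the nitro step from compound 1 to compound 3 stayed within the scatter. For compound 4 a step no larger than modest is expected, with the direction uncertain, so the estimate is a 1.5-fold lower number from compound 1 to compound 4 (0.18 log units; within the scatter), giving 1500 nM with a range from 400 nM to 6000 nM.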

Compound 4, half-maximal inhibitory concentration: 5420 nM
The estimate for compound 4 lay 3.6-fold (0.56 log units) below the measured number; the measured number falls inside the stated range.
By their numbers in this assay, from the lowest: compound 2; then compounds 1, 3 and 4 (each within the scatter of the next, the first and the last beyond it).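

In this assay, among these compounds, the only clear movement on the outer ring so far had been the lowering brought by the methyl group, whereas the step of a 2.4-fold higher number from compound 1 to compound 4 (0.37 log units; beyond the scatter) is the first to raise the number beyond the scatter, showing that replacing phenyl here can also cost activity. The step of a 1.2-fold higher number from compound 3 to compound 4 (0.08 log units; within the scatter) lies within the scatter, so the 3-nitrophenyl and 2,4-dichlorophenyl rings cannot be ordered, while the step of a 15-fold higher number from compound 2 to compound 4 (1.18 log units; beyond the scatter) leaves 3-methylphenyl as the only outer ring shown that gives a lower number than plain phenyl, with the other two substituted rings going against any rule that substitution here helps. Nothing available explains why the two chlorines give this result.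

On these data alone, the two chlorines enter together, so the share of each stays open, as does the effect of a single chlorine on this ring. Also open, as far as these compounds go, is how an outer ring carrying an amine, a carboxylic acid or a longer chain such as butyl would compare with the 3-methylphenyl ring.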